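Chloro step in a series at the assay limit

The source may hold more compounds than are shown below. What is called first, only, known or untested is meant among the compounds shown, and "the series" means these compounds.

Measured in an ADME assay on CHO cells (Cricetulus griseus) for inhibition, read by MTT assay; a higher number here means a weaker inhibitor, a lower number a stronger inhibitor:
Compound 1 `CCN(CC)Cc1cccc(Nc2nc3ccccc3[nH]2)c1O` gives > 50000 nM as a limit
Compound 2 `CCN(CC)Cc1cccc(Nc2nc3ccccc3n2Cc2ccc(C(F)(F)F)cc2)c1O` gives > 50000 nM as a limit

Compound 2 stands only at a limit, with no number to place it. Both measured compounds sit at this same boundary, the limit of > 50000 nM in this assay, at which 2 of the 2 values shown sit, in the working record.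

Compound 3 `CCN(CC)Cc1c(Cl)ccc(Nc2nc3ccccc3n2Cc2ccc(C(F)(F)F)cc2)c1O` takes chloro in place of hydrogen on an aromatic carbon of compound 2 (chloro in place of hydrogen on an aromatic carbon). Within the data shown here, the only measured step, a step that the two limits leave unreadable from compound 1 to compound 2 for 4-(trifluoromethyl)benzyl in place of hydrogen on an aromatic nitrogen, offers no size to carry over and no direction. No change beyond the scatter is therefore expected in this assay, although a number may still appear in place of a limit. The estimated step is a number no higher from compound 2 to compound 3 (the limit leaves the size open) in these notes. Compound 3 is expected at 50000 nM (15000 nM to 100000 nM).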

Compound 3, half-maximal inhibitory concentration: > 50000 nM
Compound 3: a limit, no number (the forecaster's own chance of this, stated with the estimate: 60%); the middle value sits exactly at the limit.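

In this assay, compound 2 and compound 3 both stand at a limit, so no step can be read between them: the limit of > 50000 nM in this assay, at which 3 of the 3 values shown sit.

The compounds shown leave open whether chloro or 4-(trifluoromethyl)benzyl changes inhibition in this assay at all; none of them yields a number.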